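Sulfur oxidation state on the methionine-type side chain: cytotoxicity

This account rests on a few compounds, and the source may have more. Where it says the series, first, only, none or still open, it means among the compounds named here.

Measured compounds:
- compound 1 `COC(=O)N[C@@H](CSC)C(=O)N1CCC[C@H]1c1ncc(-c2ccc(-c3ccc(-c4cnc([C@@H]5CCCN5C(=O)[C@@H](NC(=O)OC)C(C)C)[nH]4)cc3)cc2)[nH]1`: 18000 nM
- compound 2 `COC(=O)N[C@@H](CCSC)C(=O)N1CCC[C@H]1c1ncc(-c2ccc(-c3ccc(-c4cnc([C@@H]5CCCN5C(=O)[C@@H](NC(=O)OC)C(C)C)[nH]4)cc3)cc2)[nH]1`: 40000 nM
- compound 3 `COC(=O)N[C@@H](C[S+]([O-])Cc1ccccc1)C(=O)N1CCC[C@H]1c1ncc(-c2ccc(-c3ccc(-c4cnc([C@@H]5CCCN5C(=O)[C@@H](NC(=O)OC)C(C)C)[nH]4)cc3)cc2)[nH]1`: 11000 nM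

The three measured compounds share one core and differ only in the sulfur-bearing side chain. In an ADME assay on Vero cells (Chlorocebus sabaeus) for cytotoxicity (a higher number here means that more compound is tolerated, a lower number that less compound is tolerated), compound 3 holds the lowest number of the three; its nearest neighbour is compound 1, a gap that lies within the scatter, while the gap to compound 2 is beyond the scatter (a 3.6-fold lower number from compound 2 to compound 3 (0.56 log units; beyond the scatter)). The step of a 2.2-fold higher number from compound 1 to compound 2 (0.35 log units; beyond the scatter) is modest, and a 1.6-fold lower number from compound 1 to compound 3 (0.21 log units; within the scatter) is within the scatter, so the whole series spans a narrow window.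

Compound 4 `COC(=O)N[C@@H](CS(=O)(=O)Cc1ccccc1)C(=O)N1CCC[C@H]1c1ncc(-c2ccc(-c3ccc(-c4cnc([C@@H]5CCCN5C(=O)[C@@H](NC(=O)OC)C(C)C)[nH]4)cc3)cc2)[nH]1` carries the change (a group of 10 heavy atoms (7 carbon, 2 oxygen, 1 sulfur; one six-membered aromatic ring of carbon only) in place of a group of 9 heavy atoms (7 carbon, 1 oxygen, 1 sulfur; one six-membered aromatic ring of carbon only), on a saturated chain carbon, two bonds along the chain from an amide-type nitrogen and a carbonyl carbon). Among the compounds with values here, no measured pair shows this oxidation of sulfur; the steps that bear on it are the replacements of the small sulfur groups of compound 1 and compound 2 by the benzyl-bearing group of compound 3, which are the steps quoted above. Those steps are small, and the change from compound 3 to compound 4 keeps the same ring and sulfur-bearing chain, so in this assay no step beyond the scatter is expected, and the expected step is a 1.1-fold higher number from compound 3 to compound 4 (0.04 log units; within the scatter). Compound 4 is therefore estimated at 12000 nM, with a range from 5000 nM to 30000 nM.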

Compound 4, half-maximal cytotoxic concentration: > 100000 nM
Compound 4: a limit, no number; the forecaster's own chance of this, stated with the estimate: 5%; middle value at least 8.3-fold (0.92 log units) from the limit.
By their numbers in this assay, from the lowest: compounds 3 and 1 (each within the scatter of the next); then compound 2. At a limit, above all of these: compound 4.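

Compound 4 returns a limit and not a number in this assay, and it is the only one of the series to do so: the limit of > 100000 nM in this assay, at which 1 of the 4 values shown sits.
Within the data shown here, with the benzyl ring and the sulfur-bearing chain held in place, the extra oxygen on sulfur in benzylsulfonyl gives an at least 9.0-fold higher number from compound 3 to compound 4 (0.95 log units; beyond the scatter) and so shows that this position, on a saturated chain carbon, can move the read-out well outside the narrow window of the earlier compounds.
Against the two small sulfur groups, benzylsulfonyl gives an at least 2.5-fold higher number from compound 2 to compound 4 (0.39 log units; beyond the scatter) and an at least 5.5-fold higher number from compound 1 to compound 4 (0.74 log units; beyond the scatter); since compound 3 and compound 4 share the same ring, the presence of the ring alone does not set the value here, and the state of the sulfur counts for at least as much.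

Going by these compounds, how far compound 4 lies beyond its limit stays unknown, so all three steps are lower bounds and not sizes. On these data alone, whether the same gain appears with methylsulfonyl on the shorter or longer chain, or with an amine or a carboxylic acid on the benzyl ring, stays open.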